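The source may hold more compounds than are shown below. What is called first, only, known or untested is meant among the compounds shown, and "the series" means these compounds.

Compound 3 `COc1cc(Cn2cc(CNC(=O)c3cn(-c4ccccc4)nc3-c3ccc(F)cc3)nn2)cc(OC)c1OC` gives 5200 nM in a functional assay on MIA PaCa-2 cells (Homo sapiens) for antiproliferative activity, read by sulforhodamine B assay, with a stated time of 48 h (a lower number here means a stronger inhibitor of growth, a higher number a weaker inhibitor of growth), the higher of the two numbers shown, and compound 1 `COc1ccc(Cn2cc(CNC(=O)c3cn(-c4ccccc4)nc3-c3ccc(F)cc3)nn2)cc1` gives 3700 nM. The step of a 1.4-fold higher number from compound 1 to compound 3 (0.15 log units; within the scatter) stays within the scatter. Compound 2 `COc1ccc(Cn2cc(CNC(=O)c3cn(-c4ccccc4)nc3-c3ccc(F)cc3)nn2)cc1OC` reaches only the limit > 100000 nM in this assay. The large steps of an at least 27-fold higher number from compound 1 to compound 2 (1.43 log units; beyond the scatter) and an at least 19-fold lower number from compound 2 to compound 3 (1.28 log units; beyond the scatter) both turn on a methoxy added to or removed from the benzyl ring, not on the fluorophenyl side. Compound 4 `COc1ccc(-c2nn(-c3ccccc3)cc2C(=O)NCc2cn(Cc3cc(OC)c(OC)c(OC)c3)nn2)cc1` differs from compound 3 by methoxy in place of fluoro on an aromatic carbon. For the measured compounds named here, no measured step touches this position, so the expectation rests on the narrow spread between compound 1 and compound 3 alone, and a step of a 1.2-fold higher number from compound 3 to compound 4 (0.06 log units; within the scatter) is expected, within the scatter. Compound 4 is therefore estimated at 6000 nM, with a range of 2000 nM to 20000 nM.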

Compound 4, concentration for 50% growth inhibition: 31600 nM
For compound 4 the middle estimate is 5.3-fold (0.72 log units) below the measured one; the whole stated range lies below it.
By their numbers in this assay, from the lowest: compounds 1 and 3 (each within the scatter of the next); then compound 4. At a limit, above all of these: compound 2.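

Moving from 4-fluorophenyl to 4-methoxyphenyl gives a 6.1-fold higher number from compound 3 to compound 4 (0.78 log units; beyond the scatter) in this assay and shows that growth inhibition also responds to this side of the molecule, which no earlier step touched. With the 3,4,5-trimethoxyphenyl group held constant, the benzyl ring is therefore not the only place where a single change moves the number beyond the scatter. Nothing shown accounts for this step.

From the compounds shown here alone, whether the step follows the loss of fluoro or the arrival of methoxy stays open, and a hydroxyl or an amine on this carbon would help separate the two. Also open, going by these compounds, is whether the same exchange has a similar effect with the 4-methoxyphenyl group of compound 1 in place of the 3,4,5-trimethoxyphenyl group.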